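A Second Chlorine Added to Compound 2

The source may hold more compounds than are shown below. What is called first, only, known or untested is meant among the compounds shown, and "the series" means these compounds.

In an assay with adenosine receptor A1 (Rattus norvegicus) as the target (a higher number here means that more compound is needed for the effect, a lower number that less compound is needed), compound 2 `Nc1sc2c(c1C(=O)c1ccc(Cl)cc1)CCN(Cc1ccccc1)C2` gives 11300 nM. Compound 1 `Nc1sc2c(c1C(=O)c1ccccc1)CCN(Cc1cccc(Cl)c1)C2` gives 15100 nM, which lies within the scatter of that figure, while compound 3 `Nc1sc2c(c1C(=O)c1ccc(Cl)cc1)CCN(Cc1ccc(Cl)c(Cl)c1)C2` gives 32000 nM, which lies beyond it. Compound 4 `Nc1sc2c(c1C(=O)c1ccc(Cl)c(Cl)c1)CCN(Cc1ccccc1)C2` differs from compound 2 by chloro in place of hydrogen on an aromatic carbon, so that 4-chlorophenyl becomes 3,4-dichlorophenyl. Within the data shown here, the only measured step of a related kind is a 2.8-fold higher number from compound 2 to compound 3 (0.45 log units; beyond the scatter), where 3,4-dichlorophenyl replaced phenyl on the saturated chain carbon bound to the ring amine nitrogen; compound 4 carries its added chlorine on a different ring, so that step bears on it only loosely. A modest rise, or no change beyond the scatter, is therefore expected: compound 4 is estimated at 16000 nM, between 7000 nM and 40000 nM, an expected step of a 1.4-fold higher number from compound 2 to compound 4 (0.15 log units; within the scatter).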

Compound 4, half-maximal effective concentration: 9200 nM
Compound 4: middle estimate off by 1.7-fold (0.24 log units), on the high side; low and high end bracket the measured number.
By their numbers in this assay, from the lowest: compounds 4, 2 and 1 (each within the scatter of the next); then compound 3.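

In this assay, chloro in place of hydrogen on an aromatic carbon, ortho to a chloro group, leaves the number within the scatter (a 1.2-fold lower number from compound 2 to compound 4 (0.09 log units; within the scatter)). Turning 4-chlorophenyl into 3,4-dichlorophenyl here therefore differs from placing 3,4-dichlorophenyl in place of phenyl on the saturated chain carbon bound to the ring amine nitrogen, which went beyond the scatter (a 2.8-fold higher number from compound 2 to compound 3 (0.45 log units; beyond the scatter)). No measured evidence accounts for this difference. Still open, on these data alone, is whether a methoxy group, an amine or a carboxylic acid at this aromatic carbon would move the number beyond the scatter.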